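Chain lengthening on a fluorinated and a hydroxylated core

The source may report more compounds than this note shows. Statements on the series, on what has been measured and on what is new or still open speak of the compounds shown alone.

The account covers three measured compounds and one that awaits measurement. Compound 1 `CN(C)C(=O)c1cc2cnc(Nc3ccc(C(=O)NCCCCN=C=S)cc3F)nc2n1C1CCCC1` is tested in a functional assay on NCI-H1299 cells (Homo sapiens) for inhibition, read by CCK-8 assay, with a stated time of 72 h, tested at 1 uM (on this read-out lower numbers stand for a weaker effect and higher numbers for a stronger effect at the one concentration tested), where compound 1 gives 28.7%. Compound 2 `CN(C)C(=O)c1cc2cnc(Nc3ccc(C(=O)NCCCCCN=C=S)cc3F)nc2n1C1CCCC1` carries the change (a group of 4 heavy atoms (2 carbon, 1 nitrogen, 1 sulfur; no ring) in place of a group of 3 heavy atoms (1 carbon, 1 nitrogen, 1 sulfur; no ring), on a saturated chain carbon, four bonds along the chain from an amide-type nitrogen), and in this assay compound 2 gives 36.1%. The step of a number 7.4 percentage points higher from compound 1 to compound 2 (within the scatter) is small, and the two values are therefore not ordered against each other.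

Compound 3 `CN(C)C(=O)c1cc2cnc(Nc3ccc(C(=O)NCCCN=C=S)cc3O)nc2n1C1CCCC1` rests on a different core; how its core differs from that of compound 1 is not broken down here. In this assay compound 3 gives 10.3%, which lies beyond the scatter from both compound 1 and compound 2.

Compound 4 `CN(C)C(=O)c1cc2cnc(Nc3ccc(C(=O)NCCCCN=C=S)cc3O)nc2n1C1CCCC1` is the unmeasured one. It differs from compound 3 by a group of 4 heavy atoms (2 carbon, 1 nitrogen, 1 sulfur; no ring) in place of a group of 3 heavy atoms (1 carbon, 1 nitrogen, 1 sulfur; no ring), on a saturated chain carbon, three bonds along the chain from an amide-type nitrogen. This is the same kind of change as that from compound 1 to compound 2, but not the same one: there the group sits four bonds along the chain from the amide-type nitrogen, here three bonds along the chain from it.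

Because the earlier step of a number 7.4 percentage points higher from compound 1 to compound 2 (within the scatter) stayed within the scatter, the expected step for the new pair is likewise modest, estimated as a number 6.7 percentage points higher from compound 3 to compound 4 (within the scatter). On that basis compound 4 is expected to give about 17% in this assay, with the estimate spanning from 5% to 30%. The estimate rests on one prior step only and on the value of compound 3.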

Compound 4, a percentage reported as inhibition, at one concentration (the size of the read-out at that concentration, not a potency): 10.7%
The estimate for compound 4 lay 6.3 percentage points above the measured number, and the stated range covers the measured number.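

In this assay, putting the group of 4 heavy atoms in place of the group of 3 heavy atoms on the core of compound 3 gives a number 0.4 percentage points higher from compound 3 to compound 4 (within the scatter), so the change stays as small here as it was on the core of compound 1, and the two steps do not differ: the same change on two cores in this assay, a number 7.4 percentage points higher (within the scatter) from compound 1 to compound 2 and a number 0.4 percentage points higher (within the scatter) from compound 3 to compound 4, 7 percentage points apart, within the scatter of two such steps

This shows that, in these two pairs, the change carries from one core to the other without a step that can be told from the scatter, whereas hydroxy in place of fluoro on an aromatic carbon gives a number 18 percentage points lower from compound 1 to compound 4 (beyond the scatter). It does not show that the chain has no influence in this series, since the evidence is two pairs, each with a step within the scatter, read at a single concentration and at a different place along the chain in each pair.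

The compounds shown leave open whether a still longer chain on the core of compound 3 would keep the number where it stands or move it beyond the scatter. They also leave open how an amine or a carboxylic acid in place of the changed group would read on either core, and whether the step from fluoro to hydroxy has the same size at other chain lengths.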